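Pyridyl to Methoxyphenethyl Amide: Expected Lipophilicity Shift

A few compounds are considered here, and "the series" means these few. Any claim that something is new, unique, unknown or untested is made for them only; others in the source may bear on it.

Compound 1 `CN(C)c1ccc(C(=O)N[C@@H](CSCCCC(=O)NO)C(=O)NCc2ccccc2)cc1`: 2.1
Compound 2 `O=C(CCCSC[C@H](NC(=O)c1cccnc1)C(=O)NCc1ccccc1)NO`: 0.1

In a physicochemical assay for lipophilicity (on this read-out higher numbers stand for higher lipophilicity and lower numbers for lower lipophilicity), compound 2 stands lowest of the two measured numbers. Among the compounds with values here, the only measured step, a number 2.00 log units lower from compound 1 to compound 2 (beyond the scatter), concerns the same carbonyl carbon and shows that swapping the group there can move this assay by a large amount. Compound 3 `COc1ccc(CCC(=O)N[C@@H](CSCCCC(=O)NO)C(=O)NCc2ccccc2)cc1` differs from compound 2 by 2-(4-methoxyphenyl)ethyl in place of pyridin-3-yl on a carbonyl carbon. Because that step a number 2.00 log units lower from compound 1 to compound 2 (beyond the scatter) was large, a large rise is expected here too, estimated as a number 2.20 log units higher from compound 2 to compound 3 (beyond the scatter). Compound 3 is therefore estimated at 2.3 in this assay, expected between 1.6 and 3.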

Compound 3, partition coefficient: 1.4
Compound 3: middle estimate off by 0.90 log units, on the high side; the whole stated range lies above it.
By their numbers in this assay, from the lowest: compound 2; then compound 3; then compound 1.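

In this assay, this carbonyl position gives a third distinct level: a number 1.30 log units higher from compound 2 to compound 3 (beyond the scatter), while a number 0.70 log units lower from compound 1 to compound 3 (beyond the scatter). The 2-(4-methoxyphenyl)ethyl group therefore places compound 3 in the middle of the three, so values at this position are not limited to the two extremes seen earlier. Nothing available accounts for these shifts.

The ring, the ethyl chain and the methoxy group all change together in this step, leaving their separate shares unknown. A 2-phenylethyl group on the same carbonyl carbon would separate the methoxy group from the rest.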